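Fluorine Pattern on the Cyclopropyl-Linked Phenyl Ring

The source may hold more compounds than are shown below. What is called first, only, known or untested is meant among the compounds shown, and "the series" means these compounds.

Compound 3 `CC[C@H](C)[C@H](N)CN(C(=O)[C@@H]1C[C@H]1c1ccccc1F)c1ccc(-c2ccccc2)cc1` is one of three related amides that share a core built around a three-membered carbon ring carrying an aromatic group. In a functional assay for agonist activity at G protein-coupled receptor 88 (Homo sapiens), read by HTRF and cAMP accumulation (a lower number here means that less compound is needed, a higher number that more compound is needed for the effect), compound 3 gives 650 nM. Compound 2 `CC[C@H](C)[C@H](N)CN(C(=O)[C@@H]1C[C@H]1c1ccc(F)cc1)c1ccc(-c2ccccc2)cc1` gives 600 nM in this assay, and compound 1 `CC[C@H](C)[C@H](N)CN(C(=O)[C@@H]1C[C@H]1c1cccc(Cl)c1)c1ccc(-c2ccccc2)cc1` gives 2200 nM. Compound 3 thus stands second highest of the three numbers, with compound 2 nearest, since a 1.1-fold higher number from compound 2 to compound 3 (0.03 log units; within the scatter), and compound 1 furthest, since a 3.4-fold lower number from compound 1 to compound 3 (0.53 log units; beyond the scatter).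

Compound 4 `CC[C@H](C)[C@H](N)CN(C(=O)[C@@H]1C[C@H]1c1cc(F)cc(F)c1)c1ccc(-c2ccccc2)cc1` differs from compound 3 in one place: 3,5-difluorophenyl in place of 2-fluorophenyl on a saturated ring carbon. Going by the values given here, no measured step exchanges one fluorine for two, so the change is only partly covered. Among the compounds with values here, the steps that bear on it are a 3.7-fold lower number from compound 1 to compound 2 (0.56 log units; beyond the scatter) and a 3.4-fold lower number from compound 1 to compound 3 (0.53 log units; beyond the scatter), which show that a single fluorine on this ring, whether as 2-fluorophenyl or 4-fluorophenyl, gives a clearly lower number than 3-chlorophenyl, while a 1.1-fold higher number from compound 2 to compound 3 (0.03 log units; within the scatter) shows that the two fluorine placements are indistinguishable. Within the data shown here, the only compound with a group placed as in 3,5-difluorophenyl is compound 1, which gives the highest number.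

Compound 4 is therefore expected to lie between compound 3 and compound 1, a modest rise of a 1.7-fold higher number from compound 3 to compound 4 (0.23 log units; within the scatter). The estimate for compound 4 in this assay is 1100 nM, with a likely range from 400 nM to 3000 nM.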

Compound 4, half-maximal effective concentration: 960 nM
Beside the measured number, compound 4's estimate is 1.1-fold (0.06 log units) above it, within the range that was stated.
By their numbers in this assay, from the lowest: compounds 2, 3 and 4 (each within the scatter of the next); then compound 1.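

In this assay, going by these compounds alone, moving from one fluorine to two on the aromatic group, with the fluorines also placed differently, gives no step that can be told from the scatter, whether from 2-fluorophenyl (a 1.5-fold higher number from compound 3 to compound 4 (0.17 log units; within the scatter)) or from 4-fluorophenyl (a 1.6-fold higher number from compound 2 to compound 4 (0.20 log units; within the scatter)). The same 3,5-difluorophenyl group still stands apart from the 3-chlorophenyl group (a 2.3-fold lower number from compound 1 to compound 4 (0.36 log units; beyond the scatter)), so the high number of compound 1 does not carry over to it, and all three fluorine-bearing compounds now read lower than the chlorine-bearing one, with no exception among the four. Nothing measured here explains why these groups behave this way.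

The compounds shown leave open whether the number of compound 1 follows from the chlorine itself or from where it sits on the aromatic group, a question that a 3-fluorophenyl or a 4-chlorophenyl group at this position would help to separate. Also open, from the compounds shown here alone, is how this position responds to substituents other than halogens, such as a methoxy group or a nitrile on the same aromatic group.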